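This account rests on a few compounds, and the source may have more. Where it says the series, first, only, none or still open, it means among the compounds named here.

Working notes on the series: in a functional assay on HeLa cells (Homo sapiens) for antiproliferative activity, read by MTT assay, with a stated time of 72 h (on this read-out higher numbers stand for weaker inhibition and lower numbers for stronger inhibition), compound 1 (`Cc1ccccc1N1CCN(C(=S)SCc2ccc3nc(N)nc(N)c3c2)CC1`) gives "not determined" (no result reported), and compound 2 (`Cc1ccc(N2CCN(C(=S)SCc3ccc4nc(N)nc(N)c4c3)CC2)c(C)c1`) gives 3190 nM, the only number available, so compound 2 cannot yet be ranked against anything. Compound 3 (`Nc1nc(N)c2cc(CSC(=S)N3CCN(c4ccc(Cl)cc4)CC3)ccc2n1`) awaits measurement and carries one change from compound 2: 4-chlorophenyl in place of 2,4-dimethylphenyl on an amine nitrogen in a ring. Going by the values given here, no measured pair shows what this exchange does in this assay, so no step beyond the usual scatter is expected, in either direction. The expected 1.3-fold lower number from compound 2 to compound 3 (0.11 log units; within the scatter) is therefore small. For compound 3 the estimated value is 2500 nM, with a range of 700 nM to 9000 nM.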

Compound 3, half-maximal inhibitory concentration: 6990 nM
Compound 3: middle estimate off by 2.8-fold (0.45 log units), on the low side; measured number inside the range.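

In this assay, the group on the amine nitrogen in the six-membered ring now has one readable exchange: 4-chlorophenyl in place of 2,4-dimethylphenyl gives a 2.2-fold higher number from compound 2 to compound 3 (0.34 log units; beyond the scatter) in this pair. The position therefore responds to this change, modestly but beyond the scatter, with compound 2 the stronger of the two. No measurement at hand explains the step.

On these data alone, the exchange removes both methyl groups and adds chlorine together, so their separate contributions remain open. Also open, as far as these compounds go, is how an amine or a carboxylic acid on the phenyl ring would read here.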